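A few compounds are considered here, and "the series" means these few. Any claim that something is new, unique, unknown or untested is made for them only; others in the source may bear on it.

Compound 3 `CC(O)(CSc1ccccc1)c1nc(-c2ccc(Cl)cc2)no1` is one of three compounds whose cytotoxicity was measured in a functional assay on DU-145 cells (Homo sapiens) for cytotoxicity, read by MTT assay; on this read-out lower numbers stand for stronger inhibition and higher numbers for weaker inhibition. Compound 3 gives 4500 nM, the lowest of the two numbers recorded. Compound 2 `CC(O)(CSc1ccc(Cl)cc1)c1nc(-c2ccc(Cl)cc2)no1` gives 14500 nM. Compound 1 `CC(O)(CSc1ccc(Br)cc1)c1nc(-c2ccccc2)no1` gives only a limit of the assay, > 100000 nM. Within the data shown here, the single measured step between compounds that differ in one place is a 3.2-fold lower number from compound 2 to compound 3 (0.51 log units; beyond the scatter), in which hydrogen replaced chloro on an aromatic carbon.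

Compound 4 `CC(O)(CSc1ccc(Br)cc1)c1nc(-c2ccc(Cl)cc2)no1` differs from compound 3 by bromo in place of hydrogen on an aromatic carbon. Among the measured compounds shown here, this change is close to the reverse of the step from compound 2 to compound 3, which removed a chloro group from that same place, so the nearest guide is a 3.2-fold lower number from compound 2 to compound 3 (0.51 log units; beyond the scatter) read in the opposite direction; with bromo rather than chloro the size may differ, and no measured step here isolates bromo alone. Compound 4 is therefore expected to give a higher number than compound 3, with the expected step being a 2.7-fold higher number from compound 3 to compound 4 (0.43 log units; beyond the scatter). The estimate for compound 4 is 12000 nM, with a range from 4000 nM to 40000 nM.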

Compound 4, half-maximal inhibitory concentration: 6500 nM
Compound 4: the middle estimate sits 1.8-fold (0.27 log units) above what was measured; measured number inside the range.
By their numbers in this assay, from the lowest: compounds 3 and 4 (each within the scatter of the next); then compound 2. At a limit, above all of these: compound 1.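

In this assay, bromo at this place, para to a large group, cannot be told apart from hydrogen: a 1.4-fold higher number from compound 3 to compound 4 (0.16 log units; within the scatter) stays within the scatter. Chloro at the same place does not read like bromo, as a 2.2-fold lower number from compound 2 to compound 4 (0.35 log units; beyond the scatter) lies beyond the scatter, so the two halogens are not interchangeable here. The chloro that compound 1 lacks counts for much more, with an at least 15-fold lower number from compound 1 to compound 4 (1.18 log units; beyond the scatter) resting on a limit of the assay, and the loss of a chloro does not read alike in the two pairs: the same change on two cores in this assay, a 3.2-fold lower number (0.51 log units; beyond the scatter) from compound 2 to compound 3 and an at least 15-fold higher number (1.18 log units; beyond the scatter) from compound 4 to compound 1, at least 49-fold (1.69 log units) apart, beyond the scatter of two such steps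

The compounds shown leave open whether other groups at this place, such as a methoxy group or an amine, would also match hydrogen. They also leave open how a fluoro group here would compare with chloro and bromo.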